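The source may hold more compounds than are shown below. What is called first, only, known or untested is meant among the compounds shown, and "the series" means these compounds.

In a functional assay on MDA-MB-231 cells (Homo sapiens) for cytotoxicity, read by MTT assay, with a stated time of 72 h (a lower number here means a stronger inhibitor, a higher number a weaker inhibitor), three compounds have been measured so far:

Compound 1 `Cn1nc(-c2ccccc2)c2cc(C(=N)Nc3ccccc3)ncc21` gives 11100 nM.
Compound 2 `Cn1nc(-c2ccccc2)c2cc(C(=N)Nc3cccc(C(F)(F)F)c3)ncc21` gives 21400 nM.
Compound 3 `Cn1cc2cc(C(=N)Nc3ccccc3)ncc2n1` gives only a limit of the assay, > 50000 nM, that is the limit of > 50000 nM in this assay, at which 1 of the 3 values shown sits.

Compound 2 differs from compound 1 by trifluoromethyl in place of hydrogen on an aromatic carbon. That change made a 1.9-fold higher number from compound 1 to compound 2 (0.29 log units; within the scatter), a step within the usual scatter, so the two values cannot be told apart. Among the compounds with values here, compound 4 `Cn1cc2cc(C(=N)Nc3cccc(C(F)(F)F)c3)ncc2n1` has not yet been measured; it differs from compound 3 by trifluoromethyl in place of hydrogen on an aromatic carbon, the same change as the one from compound 1 to compound 2, made on a different core. How the core of compound 3 differs from that of compound 1 is not broken down here. Because compound 3 already sits at the limit of > 50000 nM in this assay, at which 1 of the 3 values shown sits, the step from compound 3 to compound 4 is expected to be small, about a step that the limit leaves unreadable from compound 3 to compound 4, resting on a 1.9-fold higher number from compound 1 to compound 2 (0.29 log units; within the scatter). Compound 4 is therefore estimated at 80000 nM, between 40000 nM and 200000 nM, and most likely reported again only as a limit.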

Compound 4, half-maximal inhibitory concentration: > 50000 nM
Compound 4: only a limit was reported; the forecaster's own chance of this, stated with the estimate: 85%; the middle value lies beyond the limit too.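

Compound 3 and compound 4 both sit at the same limit, so no step between them can be read: the limit of > 50000 nM in this assay, at which 2 of the 4 values shown sit.

The compounds shown leave open what trifluoromethyl in place of hydrogen does on the core of compound 3, and how far past the limit either compound lies.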